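The source may hold more compounds than are shown below. What is called first, only, known or untested is meant among the compounds shown, and "the series" means these compounds.

Working notes on a series with a shared core. Two compounds carry numbers in an assay for inhibition of Indoleamine 2,3-dioxygenase 1 (Homo sapiens), read by fluorescence, with a stated time of 1 h; on this read-out higher numbers stand for weaker inhibition and lower numbers for stronger inhibition. Compound 1 `NS(=O)(=O)CC(=O)NCCSc1nonc1/C(=N/O)Nc1cccc(C(F)F)c1` gives 130 nM in this assay. Compound 2 `C[C@H](CSc1nonc1/C(=N/O)Nc1ccc(F)c(Br)c1)NC(=O)CS(N)(=O)=O` gives 110 nM in this assay. Compound 2 holds the lower of the two numbers, with compound 1 the nearest, and the gap between them lies within the scatter of repeated measurements, so neither compound is set apart from the other. Compound 3 `NS(=O)(=O)CC(=O)NCCSc1nonc1/C(=N/O)Nc1ccc(F)c(Br)c1` has not been measured. It differs from compound 2 in one place: hydrogen in place of methyl on a saturated chain carbon bound to an amide-type nitrogen and a saturated chain carbon. For the measured compounds named here, no measured pair shows this change on its own, and compounds 1 and 2 differ from each other in more than one place, so they give no direction for it. A change of this kind, a single carbon leaving a saturated chain, is expected to produce a step that stays within the scatter in this assay, with no direction to be called. The step that this estimate means is expected to be a 1.2-fold higher number from compound 2 to compound 3 (0.07 log units; within the scatter). For compound 3 the estimate in this assay is 130 nM, with a range from 60 nM to 280 nM.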

Compound 3, half-maximal inhibitory concentration: 71 nM
The estimate for compound 3 lay 1.8-fold (0.26 log units) above the measured number; the measured number falls inside the stated range.
By their numbers in this assay, from the lowest: compounds 3, 2 and 1 (each within the scatter of the next).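

In this assay, hydrogen in place of methyl on a saturated chain carbon bound to an amide-type nitrogen and a saturated chain carbon gives a 1.5-fold lower number from compound 2 to compound 3 (0.19 log units; within the scatter) and so provides the first one-place reading at this position, where the methyl is not shown to set the number apart from hydrogen. For the compounds shown here, the first one-place reading on the amine nitrogen, 3-bromo-4-fluorophenyl in place of 3-(difluoromethyl)phenyl, gives a 1.8-fold lower number from compound 1 to compound 3 (0.26 log units; within the scatter) and also leaves the two compounds unseparated, so neither change shows a direction in this assay. Nothing at hand bears on the cause of either step.

As far as these compounds go, each change is read only once, so it remains open whether the methyl-to-hydrogen step would stay within the scatter with 3-(difluoromethyl)phenyl on the amine nitrogen. Also open is what an ethyl group, a longer chain or a carboxylic acid would do on the same saturated chain carbon, since methyl and hydrogen are the only two groups shown there.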